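From Bromo to Nitro on the Shared Core

A few compounds are considered here, and "the series" means these few. Any claim that something is new, unique, unknown or untested is made for them only; others in the source may bear on it.

Three compounds share one core. In a functional assay on the whole organism (strain Albino Wistar) for inhibition, with Rattus norvegicus as the target, read by paw edema, with stated times of 1 h and 5 h, at a dose of 10 mg/kg by the oral route (on this read-out higher numbers stand for more inhibition at the one dose given (going by the name of the read-out) and lower numbers for less inhibition), compound 1 `Clc1ccc(-n2cc(CSc3nc4ccccc4s3)nn2)cc1` gives 43.4%, compound 2 `Fc1ccc(-n2cc(CSc3nc4ccccc4s3)nn2)cc1` gives 81.1%, and compound 3 `Brc1ccc(-n2cc(CSc3nc4ccccc4s3)nn2)cc1` gives 59.2%. Compound 3 stands second highest of the three: a number 15.8 percentage points higher from compound 1 to compound 3 (beyond the scatter), while a number 21.9 percentage points lower from compound 2 to compound 3 (beyond the scatter). Compound 4 `O=[N+]([O-])c1ccc(-n2cc(CSc3nc4ccccc4s3)nn2)cc1` differs from compound 3 in one place: nitro in place of bromo on an aromatic carbon. Every measured step exchanges one halogen for another on an aromatic carbon, and each was sizeable, for example a number 37.7 percentage points higher from compound 1 to compound 2 (beyond the scatter) and a number 15.8 percentage points higher from compound 1 to compound 3 (beyond the scatter). Going by the values given here, no measured step involves a nitro group, so the direction for compound 4 is open, and a step beyond the scatter either way is plausible. Compound 4 is therefore expected near the middle of the spread, at 55%, within 35% to 78%. The expected step is a number 4.2 percentage points lower from compound 3 to compound 4 (within the scatter).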

Compound 4, a percentage reported as inhibition, in the whole organism at one dose (the size of the read-out at that dose, not a potency): 65.5%
For compound 4 the middle estimate is 10.5 percentage points below the measured one, within the range that was stated.
By their numbers in this assay, from the lowest: compound 1; then compounds 3 and 4 (each within the scatter of the next); then compound 2.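

In this assay, a group that is not a halogen can hold this place on the aromatic carbon, with a number 6.3 percentage points higher from compound 3 to compound 4 (within the scatter), so nitro and bromo cannot be told apart here. Nitro still stays short of fluoro, with a number 15.6 percentage points lower from compound 2 to compound 4 (beyond the scatter), and ahead of chloro, with a number 22.1 percentage points higher from compound 1 to compound 4 (beyond the scatter), which places it inside the span the halogens already mark. Nothing shown here accounts for these differences. On these data alone, whether an amine or a carboxylic acid at this place would keep the inhibition remains open.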